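The source may report more compounds than this note shows. Statements on the series, on what has been measured and on what is new or still open speak of the compounds shown alone.

The series shares one core and is varied at the benzylamine. Compound 1 `CCOC(=O)c1sc(-c2ccccn2)nc1N1CCC(NCc2cccc(C(F)(F)F)c2)CC1` gives 19.2% in an ADME assay on RAW264.7 cells (Mus musculus) for cytotoxicity, read by MTT assay, with a stated time of 72 h, tested at 50 uM; a lower number here means less inhibition, a higher number more inhibition at the concentration tested (going by the name of the read-out). Compound 2 `CCOC(=O)c1sc(-c2ccncc2)nc1N1CCC(NCc2ccc(OC)cc2)CC1` gives 16.1% in the same assay, and compound 3 `CCOC(=O)c1sc(-c2ccncc2)nc1N1CCC(NCc2ccc(C(F)(F)F)cc2)CC1` gives 18.1%. Compound 3 stands second highest of the three numbers, yet its separation from compound 1 and from compound 2 is within the scatter, so no order among them can be read. Among the measured compounds shown here, the one measured step is a number 2 percentage points higher from compound 2 to compound 3 (within the scatter).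

Compound 4 `CCOC(=O)c1sc(-c2ccncc2)nc1N1CCC(NCc2cccc(C(F)(F)F)c2)CC1` differs from compound 3 by 3-(trifluoromethyl)phenyl in place of 4-(trifluoromethyl)phenyl on a saturated chain carbon bound to an amine nitrogen. For the measured compounds named here, no measured step matches this change directly. Compound 1 carries the same 3-(trifluoromethyl)benzyl as compound 4 but differs in its core, so its value and that of compound 3 only show two numbers within the scatter of each other. Because compound 3 gives 18.1% and the measured step of a number 2 percentage points higher from compound 2 to compound 3 (within the scatter) was small, compound 4 is expected to give 18.5%, in the range 11% to 26%. The expected step of a number 0.4 percentage points higher from compound 3 to compound 4 (within the scatter) lies within the scatter.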

Compound 4, a percentage reported as inhibition, at one concentration (the size of the read-out at that concentration, not a potency): 14.3%
Estimate against measurement, compound 4: 4.2 percentage points above, within the range that was stated.
By their numbers in this assay, from the lowest: compounds 4, 2, 3 and 1 (each within the scatter of the next).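

In this assay, the first direct test of 3-(trifluoromethyl)phenyl in place of 4-(trifluoromethyl)phenyl on a saturated chain carbon bound to an amine nitrogen gives a number 3.8 percentage points lower from compound 3 to compound 4 (within the scatter), and 3-(trifluoromethyl)phenyl in place of 4-methoxyphenyl at that same place gives a number 1.8 percentage points lower from compound 2 to compound 4 (within the scatter). With the benzylamine held constant, pyridin-4-yl in place of pyridin-2-yl on an aromatic carbon gives a number 4.9 percentage points lower from compound 1 to compound 4 (within the scatter), so each of the three single changes stays within the scatter. Nothing available accounts for these numbers.

The compounds shown carry only trifluoromethyl and methoxy on the benzyl group, so it remains open whether an amine or a carboxylic acid there would move the read-out beyond the scatter. They also leave open what a longer chain in place of the benzyl group would give.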